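Swapping the ring substituent on the aryl ether of compound 1

The compounds below may be only part of what the source reports. "The series", "measured", "known", "first", "only" and "open" are said of these compounds alone.

Among the measured compounds shown here, compound 1 `CCC1(O)CCN(c2nc(C)c3cc(NC(=O)COc4ccc(OC(F)(F)F)cc4)ccc3n2)CC1` is one of three compounds measured in a functional assay on CHO-K1 cells for antagonist activity at melanin-concentrating hormone receptor 1 (Homo sapiens), read by inositol phosphate accumulation; on this read-out higher numbers stand for weaker inhibition and lower numbers for stronger inhibition. In this assay compound 1 gives 59 nM, the highest of the three numbers. Compound 2 `Cc1nc(N2CCN(C(=O)C3CCC3)CC2)nc2ccc(NC(=O)COc3ccc(OC(F)(F)F)cc3)cc12` gives 45 nM, and compound 3 `Cc1nc(N2CCC(O)(C3CC3)CC2)nc2ccc(NC(=O)COc3ccc(OC(F)(F)F)cc3)cc12` gives 33 nM. The three steps among them are all small: a 1.3-fold lower number from compound 1 to compound 2 (0.12 log units; within the scatter), a 1.8-fold lower number from compound 1 to compound 3 (0.25 log units; within the scatter) and a 1.4-fold lower number from compound 2 to compound 3 (0.13 log units; within the scatter). Every one of these steps changes the saturated ring attached to the shared core, and none touches the aryl ether at the other end of the molecule.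

Compound 4 `CCC1(O)CCN(c2nc(C)c3cc(NC(=O)COc4ccc(Cl)cc4)ccc3n2)CC1` differs from compound 1 at exactly that other end: chloro in place of trifluoromethoxy on an aromatic carbon. For the measured compounds named here, no measured step bears on this position, so there is nothing in the data to show how the outer ring substituent moves the number in this assay. Going by the values given here, the only guide is that the three changes measured so far each stayed within the scatter, and the change to compound 4 is similarly modest in size. The expectation is therefore no step beyond the scatter, as a 1.2-fold higher number from compound 1 to compound 4 (0.07 log units; within the scatter), with wide uncertainty. Compound 4 is estimated at 70 nM, in the range 25 nM to 200 nM.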

Compound 4, half-maximal inhibitory concentration: 384 nM
The estimate for compound 4 lay 5.5-fold (0.74 log units) below the measured number; measured number above the stated range.
By their numbers in this assay, from the lowest: compounds 3, 2 and 1 (each within the scatter of the next); then compound 4.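

This step shows that the outer end of the molecule matters in this assay: with chloro in place of trifluoromethoxy, on an aromatic carbon para to a large group, there is a 6.5-fold higher number from compound 1 to compound 4 (0.81 log units; beyond the scatter) and so weaker inhibition. Among these compounds it is the only step beyond the scatter, while the three changes to the saturated ring attached to the shared core all stayed within it, so the number here responds more to this single swap at the aryl ether than to any of those ring changes. Nothing available bears on why this swap weakens inhibition, so the result records the size of the change but gives no explanation for it.

Only trifluoromethoxy and chloro are shown at this position, which leaves open whether other groups, such as a methyl, a trifluoromethyl or a nitrile, would keep the number near that of compound 1 or raise it towards that of compound 4. From the compounds shown here alone, it also remains open whether the same swap would have an effect of similar size on compound 2 or compound 3, which carry different saturated rings.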